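A few compounds are considered here, and "the series" means these few. Any claim that something is new, unique, unknown or untested is made for them only; others in the source may bear on it.

Measured so far in a functional assay on CHOK cells for antagonist activity at growth hormone secretagogue receptor type 1 (Homo sapiens), read by calcium flux; on this read-out lower numbers stand for stronger inhibition and higher numbers for weaker inhibition:
compound 1 `CCc1nc(N)nc(N)c1-c1ccc(NCc2cc(F)c(S(C)(=O)=O)c(F)c2)cc1` gives 45 nM
compound 2 `Nc1nc(N)c(-c2ccc(NCc3csc(Cl)c3)cc2)c(COCc2ccccc2)n1` gives 170 nM
compound 3 `Nc1nc(N)c(-c2ccc(NCc3ccc(Cl)cc3)cc2)c(CCc2ccccc2)n1` gives 3350 nM

Compound 2 holds the second highest number of the three: compound 1 sits lower and compound 3 higher, and both gaps lie beyond the usual scatter of this assay. Compound 4 `Nc1nc(N)c(-c2ccc(CNc3ccc([N+](=O)[O-])cc3)cc2)c(COCc2ccccc2)n1` has not yet been tested. It differs from compound 2 in one place: ((4-nitrophenyl)amino)methyl in place of ((5-chlorothiophen-3-yl)methyl)amino on an aromatic carbon. Within the data shown here, no measured pair isolates a change of this kind, so any expectation is loosely founded. The only compound with a carbon-only ring on that arm, compound 3, gives 3350 nM, the highest number shown, though its other side chain differs as well. A step toward a weaker inhibition, beyond the scatter, is therefore expected from compound 2 to compound 4, about a 4.7-fold higher number from compound 2 to compound 4 (0.67 log units; beyond the scatter). Compound 4 is estimated at 800 nM, within a range from 150 nM to 4000 nM.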

Compound 4, half-maximal inhibitory concentration: 16 nM
Beside the measured number, compound 4's estimate is 50-fold (1.70 log units) above it; measured number outside the range, below it.
By their numbers in this assay, from the lowest: compound 4; then compound 1; then compound 2; then compound 3.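

In this assay, among these compounds, putting ((4-nitrophenyl)amino)methyl in place of ((5-chlorothiophen-3-yl)methyl)amino gives an 11-fold lower number from compound 2 to compound 4 (1.03 log units; beyond the scatter), the first step that can be read at this position. So this aromatic carbon accepts an arm with more heavy atoms and a carbon-only ring, and inhibition still grows stronger. Nothing shown accounts for the step.

On these data alone, the ring, its substituent and the order of the linking atoms all change together, so the part that carries the step stays open. A nitrile or a chlorine in place of the nitro group, on the same arm, would begin to separate these parts.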